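Isopropyl replacing dimethoxypropyl on the ring nitrogen

The compounds below may be only part of what the source reports. "The series", "measured", "known", "first", "only" and "open" are said of these compounds alone.

Of the compounds shown here, two have been measured in a functional assay on HepG2 cells (Homo sapiens) for antiproliferative activity, read by CCK-8 assay, with a stated time of 72 h, tested at 8 uM; on this read-out lower numbers stand for a weaker effect and higher numbers for a stronger effect at the one concentration tested. Compound 1 `COC(CCn1cnc2c(NCc3ccc(C(=O)Nc4ccccc4N)cc3)nc(Cl)nc21)OC` carries a 3,3-dimethoxypropyl chain on the aromatic nitrogen of its fused core; in this assay compound 1 gives 34.2%. Compound 2 `Nc1ccccc1NC(=O)c1ccc(COCNc2nc(Nc3ccccc3)c3ncn(C4CCCC4)c3n2)cc1`, built around a related core with different substituents, gives 66.9% in this assay. Compound 1 thus stands lowest of the two numbers, and the gap to compound 2 lies beyond the scatter. Among the measured compounds shown here, no pair of measured compounds differs in a single place, so no measured step is available to show what a change at the ring nitrogen does in this assay.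

Compound 3 `CC(C)n1cnc2c(NCc3ccc(C(=O)Nc4ccccc4N)cc3)nc(Cl)nc21` is the next compound to be measured. It differs from compound 1 only at the aromatic nitrogen: isopropyl in place of 3,3-dimethoxypropyl on an aromatic nitrogen. The chain that leaves is the longer one and carries acceptors; what enters is a short branched alkyl without any. For the measured compounds named here, with no measured step to lean on, the step expected in this assay is a number 3.8 percentage points higher from compound 1 to compound 3 (within the scatter), small, of uncertain direction, and most likely within the scatter. Compound 3 is accordingly estimated at 38%, with a range from 22% to 55%.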

Compound 3, a percentage reported as inhibition, at one concentration (the size of the read-out at that concentration, not a potency): 74.4%
Compound 3: the middle estimate sits 36.4 percentage points below what was measured; measured number above the stated range.
By their numbers in this assay, from the lowest: compound 1; then compounds 2 and 3 (each within the scatter of the next).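

In this assay, the group on the aromatic nitrogen is now shown to carry a large effect: isopropyl in place of 3,3-dimethoxypropyl gives a number 40.2 percentage points higher from compound 1 to compound 3 (beyond the scatter), the first step in the series that can be read at a single place. The rest of the structure is the same in both compounds, so the whole step belongs to this one exchange, in which a chain of 7 heavy atoms with 2 hydrogen-bond acceptors gives way to a branched group of 3 heavy atoms with none. Nothing available explains the step.

Chain size, branching and the two oxygens all change together in this single step, so their shares remain unresolved; a straight propyl chain would address the oxygens, while a 3-methoxypropyl chain or a chain ending in a primary amine would test what a shorter or differently ended substituent does at the same nitrogen. Also open, as far as these compounds go, is whether a step of this size would recur on a core carrying other substituents, since one pair of compounds supports no pattern beyond itself.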